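The compounds below may be only part of what the source reports. "The series", "measured", "known", "first", "only" and "open" are said of these compounds alone.

Three compounds have been measured in an ADME assay on RAW264.7 cells (Mus musculus) for cytotoxicity, read by MTT assay, with a stated time of 48 h; a higher number here means a weaker inhibitor, a lower number a stronger inhibitor:

Compound 1, `Cc1cc(NC(=O)c2ccc(C#N)cc2)ccc1NS(C)(=O)=O`: 171000 nM
Compound 2, `COc1cc(NC(=O)c2ccc(C#N)cc2)ccc1NS(C)(=O)=O`: a limit of the assay only, > 250000 nM
Compound 3, `CS(=O)(=O)Nc1ccc(NC(=O)c2ccc(Cl)cc2)cc1Cl`: 79900 nM

Among the two numbers, compound 3 gives the lowest; compound 1 gives a higher number. The value of compound 2 is a limit of the assay, not a number, and the limit of > 250000 nM in this assay, at which 1 of the 3 values shown sits, marks it as such. Within the data shown here, the only single-point step measured, an at least 1.4-fold higher number from compound 1 to compound 2 (0.16 log units; that floor lies within the scatter), exchanges a methyl for a methoxy on the ring that carries the sulfonamide.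

Compound 4, `CS(=O)(=O)Nc1ccc(NC(=O)c2ccc(C#N)cc2)cc1Cl`, differs from compound 3 by cyano in place of chloro on an aromatic carbon. Among the measured compounds shown here, no measured step exchanges chloro for cyano on its own: compound 1 carries cyano on that ring but also differs from compound 3 at the other ring, so the gap between compound 1 and compound 3 cannot be tied to this change alone. The expected step for compound 4 is therefore a 1.4-fold higher number from compound 3 to compound 4 (0.14 log units; within the scatter), none beyond the scatter. Compound 4 is estimated at 110000 nM, between 50000 nM and 250000 nM.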

Compound 4, half-maximal inhibitory concentration: > 250000 nM
Compound 4 was reported as a limit (the forecaster's own chance of this, stated with the estimate: 20%); middle value at least 2.2-fold (0.35 log units) from the limit.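

In this assay compound 4 gives > 250000 nM, which is a limit of the assay and not a number: the limit of > 250000 nM in this assay, at which 2 of the 4 values shown sit.

Cyano in place of chloro, on an aromatic carbon para to a large group, can now be read on its own as an at least 3.1-fold higher number from compound 3 to compound 4 (0.49 log units; beyond the scatter), so this single change moves the number clearly upward, towards a weaker inhibitor. With cyano held constant, chloro in place of methyl gives an at least 1.4-fold higher number from compound 1 to compound 4 (0.16 log units; that floor lies within the scatter), while the step between compound 2 and compound 4 joins two limits and cannot be read.

Going by these compounds, the true size of both readable steps stays open, as the number for compound 4 lies beyond what the assay reports. Also open, on these data alone, is where an amine or a carboxylic acid at this same place would fall relative to chloro and cyano.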